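The compounds below may be only part of what the source reports. "The series", "measured", "known", "first", "only" and "open" are said of these compounds alone.

Compound 1 `CCOC(=O)CNC(=O)/C=C/c1ccc(O)c(O)c1`: 18600 nM
Compound 2 `CCOC(=O)[C@@H](NC(=O)/C=C/c1ccc(O)c(O)c1)C(C)C`: 19600 nM
Compound 3 `CCOC(=O)[C@H](CC(C)C)NC(=O)/C=C/c1ccc(O)c(OC)c1`: 56100 nM

All three were measured in a functional assay, read by spectrophotometry, with a stated time of 30 min; on this read-out lower numbers stand for stronger inhibition and higher numbers for weaker inhibition. Compound 3 gives the highest number of the three, beyond the scatter from both compound 1 and compound 2. Compound 4 `CCOC(=O)[C@H](CC(C)C)NC(=O)/C=C/c1ccc(O)c(O)c1` has not been measured. It differs from compound 3 in one place: hydrogen in place of methyl on an oxygen on an aromatic ring, so the methoxy of compound 3 becomes a hydroxy, as in compound 1 and compound 2. Among the compounds with values here, the only measured single-change step, a 1.1-fold higher number from compound 1 to compound 2 (0.02 log units; within the scatter), concerns the chain carbon, not the aromatic oxygen, so no measured step matches this change directly. Still, compound 1 and compound 2, which both carry two hydroxy groups, give lower numbers than compound 3. Compound 4 is therefore expected to move downward, roughly a 2.8-fold lower number from compound 3 to compound 4 (0.45 log units; beyond the scatter). The estimate for compound 4 is 20000 nM, within 8000 nM to 50000 nM.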

Compound 4, half-maximal inhibitory concentration: 28600 nM
Estimate against measurement, compound 4: 1.4-fold (0.16 log units) below; measured number inside the range.
By their numbers in this assay, from the lowest: compounds 1, 2, 4 and 3 (each within the scatter of the next, the first and the last beyond it).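

In this assay, hydrogen in place of methyl on the aromatic oxygen, methoxy to hydroxy, gives a 2.0-fold lower number from compound 3 to compound 4 (0.29 log units; within the scatter), so this direct comparison shows no clear change at this position. On the saturated chain carbon, isobutyl gives a 1.5-fold higher number from compound 2 to compound 4 (0.16 log units; within the scatter) and a 1.5-fold higher number from compound 1 to compound 4 (0.19 log units; within the scatter), so hydrogen, isopropyl and isobutyl cannot be told apart there. No measurement at hand explains these results.

Still open, on these data alone, is whether a larger group on that aromatic oxygen, such as benzyloxy, would move the number. Also open, as far as these compounds go, is whether a carboxylic acid in place of the ethyl ester would do so.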